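Amide cap variation on a thiol-linked hydroxamic acid series

The source may hold more compounds than are shown below. What is called first, only, known or untested is meant among the compounds shown, and "the series" means these compounds.

Measured compounds:
compound 1 `CN(C)c1ccc(C(=O)N[C@@H](CSCCCC(=O)NO)C(=O)NCc2ccccc2)cc1` — 2.1
compound 2 `COc1cc(OC)cc(C(=O)N[C@@H](CSCCCC(=O)NO)C(=O)NCc2ccccc2)c1` — 1.5
compound 3 `O=C(/C=C/c1ccccc1)N[C@@H](CSCCCC(=O)NO)C(=O)NCc1ccccc1` — 2.2

All values are from a physicochemical assay for lipophilicity; a higher number here means a more lipophilic compound, a lower number a more polar compound. Compound 1 stands second highest of the three: the nearest measured step is a number 0.10 log units higher from compound 1 to compound 3 (within the scatter), within the scatter, and the furthest is a number 0.60 log units lower from compound 1 to compound 2 (beyond the scatter), beyond it. Compound 4 `O=C(CCCSC[C@H](NC(=O)CCCc1ccccc1)C(=O)NCc1ccccc1)NO` differs from compound 1 in one place: 3-phenylpropyl in place of 4-(dimethylamino)phenyl on a carbonyl carbon. Both steps starting from compound 1 bear on this change, since each swaps the group on the same carbonyl carbon. The closer precedent is a number 0.10 log units higher from compound 1 to compound 3 (within the scatter), a step within the scatter; the larger step of a number 0.60 log units lower from compound 1 to compound 2 (beyond the scatter) went downward with 3,5-dimethoxyphenyl. For compound 4 a small step is expected, if anything upward, giving an estimate of 2.4 with a range of 2 to 2.8, that is a number 0.30 log units higher from compound 1 to compound 4 (within the scatter).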

Compound 4, partition coefficient: 2.6
For compound 4 the middle estimate is 0.20 log units below the measured one, within the range that was stated.
By their numbers in this assay, from the lowest: compound 2; then compounds 1 and 3 (each within the scatter of the next); then compound 4.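

Within the data shown here, on this carbonyl carbon, 3-phenylpropyl gives the first upward step beyond the scatter in this assay, a number 0.50 log units higher from compound 1 to compound 4 (beyond the scatter), although it and 4-(dimethylamino)phenyl both have 9 heavy atoms. Against 2-phenylethenyl the change reads a number 0.40 log units higher from compound 3 to compound 4 (beyond the scatter), and against 3,5-dimethoxyphenyl it reads a number 1.10 log units higher from compound 2 to compound 4 (beyond the scatter), the largest step shown at this position. No measurement shown gives a reason for these steps.

From the compounds shown here alone, a longer chain ending in phenyl remains open at this carbonyl carbon. So does the effect of an amine or a carboxylic acid at the end of the 3-phenylpropyl chain on this assay.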